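The source may hold more compounds than are shown below. What is called first, only, known or untested is meant among the compounds shown, and "the series" means these compounds.

Measured so far in a functional assay on HeLa cells (Homo sapiens) for cytotoxicity, read by MTT assay, with a stated time of 48 h; a lower number here means a stronger inhibitor, a higher number a weaker inhibitor:

Compound 1, `O=C(O)CN1C(=O)/C(=C/c2nc3ccccc3n2Cc2ccc(F)cc2)SC1=S`: 13900 nM
Compound 2, `O=C(O)CN1C(=O)/C(=C/c2nc3ccccc3n2Cc2ccc(Cl)cc2)SC1=S`: 8720 nM
Compound 3, `O=C(O)CN1C(=O)/C(=C/c2nc3cc(Cl)ccc3n2Cc2ccccc2F)SC1=S`: 9520 nM

Compound 1 and compound 2 differ only by fluoro in place of chloro on an aromatic carbon, and that change gave a 1.6-fold higher number from compound 2 to compound 1 (0.20 log units; within the scatter). The difference between the cores of compound 2 and compound 3 is not broken down here. Compound 4, `O=C(O)CN1C(=O)/C(=C/c2nc3cc(F)ccc3n2Cc2ccccc2F)SC1=S`, is still unmeasured; it differs from compound 3 by fluoro in place of chloro on an aromatic carbon. This is the same kind of change as that from compound 2 to compound 1, but the place differs: in compound 2 the site is para to a large group, while in compound 3 it lies in a ring that is part of a fused or bridged system of two rings, meta and para to a fused ring. Because a 1.6-fold higher number from compound 2 to compound 1 (0.20 log units; within the scatter) stayed within the scatter, compound 4 is expected to show a similarly small step, a 1.2-fold higher number from compound 3 to compound 4 (0.08 log units; within the scatter). Compound 4 is therefore estimated at 11500 nM in this assay, with a likely range from 6000 nM to 24000 nM.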

Compound 4, half-maximal inhibitory concentration: > 50000 nM
Compound 4 was reported as a limit (the forecaster's own chance of this, stated with the estimate: 5%); at least 4.3-fold (0.63 log units) between middle value and limit.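

In this assay, fluoro in place of chloro on an aromatic carbon gave an at least 5.2-fold higher number from compound 3 to compound 4 (0.72 log units; beyond the scatter), so this change did not carry over at a single size from one core to the other: the same change on two cores in this assay, a 1.6-fold higher number (0.20 log units; within the scatter) from compound 2 to compound 1 and an at least 5.2-fold higher number (0.72 log units; beyond the scatter) from compound 3 to compound 4, at least 3.2-fold (0.51 log units) apart, beyond the scatter of two such steps. Compound 4 is reported only as a limit, so its step has no known upper end: the limit of > 50000 nM in this assay, at which 1 of the 4 values shown sits. The two cores differ in more than one place, and the swap itself sits at a different site on each, so one pair per core cannot show which of these differences matters.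

The compounds shown leave open how other groups, such as a methoxy group or an amine, would behave at the site on the fused ring. They also leave open whether the same swap would give a large step on any further core.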